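The source may report more compounds than this note shows. Statements on the series, on what has been measured and on what is new or still open speak of the compounds shown alone.

Compound 3 `c1ccc(C(/N=C2\CCCCN2)c2ccco2)cc1` stands lowest of the three numbers in a functional assay on the whole organism (plasma, strain Sprague-Dawley) with Rattus norvegicus as the target, with a stated time of 2 h, at a dose of 100 mg/kg by the oral route (on this read-out lower numbers stand for a weaker effect and higher numbers for a stronger effect at the one dose given), where compound 3 gives 27%; compound 2 `c1csc(C(/N=C2\CCCCN2)C2CC2)c1` gives 28% and compound 1 `c1ccc(C(/N=C2\CCCCN2)C2CC2)cc1` gives 36%, both within the scatter of compound 3. The step of a number 9 percentage points lower from compound 1 to compound 3 (within the scatter) is the only measured one that touches the group on the saturated chain carbon bound to an aromatic carbon and a double-bonded nitrogen. Compound 4 `c1ccc(C(/N=C2\CCCCN2)c2cccs2)cc1` carries the change (thiophen-2-yl in place of furan-2-yl on a saturated chain carbon bound to an aromatic carbon and a double-bonded nitrogen). For the measured compounds named here, the one bearing step was small, and compound 1 and compound 2, which differ elsewhere, also show values within the scatter of each other. No shift beyond the scatter is therefore expected for a number 3 percentage points higher from compound 3 to compound 4 (within the scatter). Compound 4 is expected to give 30%, with a range from 15% to 45%.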

Compound 4, a percentage reported as inhibition, in the whole organism at one dose (the size of the read-out at that dose, not a potency): 32%
Beside the measured number, compound 4's estimate is 2 percentage points below it, within the range that was stated.
By their numbers in this assay, from the lowest: compounds 3, 2, 4 and 1 (each within the scatter of the next).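

Thiophen-2-yl in place of furan-2-yl on a saturated chain carbon bound to an aromatic carbon and a double-bonded nitrogen gives a number 5 percentage points higher from compound 3 to compound 4 (within the scatter) in this assay and so these two rings are not separated at this position. Phenyl in place of cyclopropyl gives a number 4 percentage points higher from compound 2 to compound 4 (within the scatter) and thiophen-2-yl in place of cyclopropyl gives a number 4 percentage points lower from compound 1 to compound 4 (within the scatter) so cyclopropyl is not separated from the aromatic groups here either. No further data are at hand to explain these numbers.

As far as these compounds go, whether an amine, a carboxylic acid or a longer chain at this position would give a step beyond the scatter remains open.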